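This account rests on a few compounds, and the source may have more. Where it says the series, first, only, none or still open, it means among the compounds named here.

Measured compounds:
compound 1, `COC(=O)C1=C(C)N(C)C(=O)NC1c1ccsc1`: 24%
compound 2, `CCOC(=O)C1=C(C)N(C)C(=O)NC1c1ccsc1`: 32%
compound 3, `CCCC(=O)C1=C(C)NC(=O)NC1c1ccoc1`: 1%

All three values come from an assay on membranes from CHO cells for displacement of a labelled ligand from adenosine receptor A1 (Homo sapiens), read by scintillation counting, with a stated time of 60 min, tested at 1 uM; a lower number here means less inhibition, a higher number more inhibition at the concentration tested (going by the name of the read-out). Compound 1 and compound 2 share a core and differ in one place, (methyl in place of hydrogen on a saturated chain carbon bound to an oxygen next to a carbonyl group); this gives a number 8 percentage points higher from compound 1 to compound 2 (within the scatter), so the two readings are not distinguished by this assay. Compound 3 has a different core; how the core of compound 3 differs from the core of compound 1 is not broken down here. For the measured compounds named here, its reading stands lowest of the three, beyond the scatter against compound 1 and against compound 2, and no single-place step connects it to either.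

Compound 4, `CC1=C(C(=O)CC(C)C)C(c2ccoc2)NC(=O)N1`, is not yet measured. It differs from compound 3 in one place, (methyl in place of hydrogen on a saturated chain carbon bound to two saturated chain carbons). This is the same kind of change as that from compound 1 to compound 2, but not the same: there the place was on a saturated chain carbon bound to an oxygen next to a carbonyl group, here it is on a saturated chain carbon bound to two saturated chain carbons. Going by the values given here, the only measured instance of this kind of change, a number 8 percentage points higher from compound 1 to compound 2 (within the scatter), sits within the scatter. On that basis the expected step is a number 4 percentage points higher from compound 3 to compound 4 (within the scatter), small and of uncertain sign. Because compound 3 gives 1%, compound 4 is expected to give 5% in this assay, estimated to lie between 0% and 18%.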

Compound 4, a percentage reported as inhibition, at one concentration (the size of the read-out at that concentration, not a potency): 23%
For compound 4 the middle estimate is 18 percentage points below the measured one, outside the stated range (above it).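

In this assay, methyl in place of hydrogen on a saturated chain carbon bound to two saturated chain carbons gives a number 22 percentage points higher from compound 3 to compound 4 (beyond the scatter). Set beside the earlier step, the same kind of change does not read differently on the two cores, as far as two steps can tell: the same change on two cores in this assay, a number 8 percentage points higher (within the scatter) from compound 1 to compound 2 and a number 22 percentage points higher (beyond the scatter) from compound 3 to compound 4, 14 percentage points apart, within the scatter of two such steps

For the compounds shown here, this does not show that the change carries from one core to another with a fixed size, since only two pairs stand behind it, one step lies within the scatter and the other beyond it, and the place is not the same in the two pairs: a saturated chain carbon bound to an oxygen next to a carbonyl group in one, a saturated chain carbon bound to two saturated chain carbons in the other.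

Still open, on these data alone, is how the reading responds to other groups in place of the isobutylcarbonyl of compound 4, such as a longer chain, a cyclopropyl group, an amine or a carboxylic acid. The compounds shown also leave open whether the readings at a single concentration would translate into potency, and how the same changes read at other adenosine receptors.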